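The source may report more compounds than this note shows. Statements on the series, on what has been measured and on what is new or still open speak of the compounds shown alone.

Measured compounds in a functional assay on DU-145 cells (Homo sapiens) for cytotoxicity; on this read-out lower numbers stand for stronger inhibition and higher numbers for weaker inhibition:
- compound 1, `COc1ccc(Cn2cc(/C=N\NC(=O)c3c[nH]c4ccccc34)c3ccccc32)cc1`, gives 43900 nM
- compound 2, `COc1ccc(Cn2cc(/C=N\NC(=O)c3c[nH]c4ccccc34)c3cc(OC)ccc32)cc1`, gives 19100 nM
- compound 3, `COc1ccc2c(c1)c(/C=N\NC(=O)c1c[nH]c3ccc(Br)cc13)cn2Cc1ccc(Cl)cc1`, gives 57000 nM

Compound 1 sits second highest of the three numbers in this assay. Compound 3 lies close to it, and the two values cannot be told apart within the usual scatter. Compound 2 stands apart: the step of a 2.3-fold lower number from compound 1 to compound 2 (0.36 log units; beyond the scatter) is a modest gain that does lie beyond the scatter.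

Compound 4, `COc1ccc(Cn2cc(/C=N\NC(=O)c3c[nH]c4ccccc34)c3ccc(F)cc32)cc1`, is not yet measured. It differs from compound 1 by fluoro in place of hydrogen on an aromatic carbon. Going by the values given here, the only measured step that touches the same part of the shared core is the one from compound 1 to compound 2, where a methoxy enters on that ring, though at a different place, and it gave the modest gain noted above. Among the compounds with values here, a fluoro is a different group, and the single available step offers only loose guidance; no measured step shows what a fluoro does here. On that basis the expected change from compound 1 to compound 4 is small, at most a slight gain, a 1.3-fold lower number from compound 1 to compound 4 (0.10 log units; within the scatter). The expected value for compound 4 in this assay is 35000 nM, with a range from 15000 nM to 80000 nM.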

Compound 4, half-maximal inhibitory concentration: 16200 nM
Estimate against measurement, compound 4: 2.2-fold (0.33 log units) above, within the range that was stated.
By their numbers in this assay, from the lowest: compounds 4 and 2 (each within the scatter of the next); then compounds 1 and 3 (each within the scatter of the next).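

In this assay, a fluoro in place of hydrogen on the shared core gives a 2.7-fold lower number from compound 1 to compound 4 (0.43 log units; beyond the scatter), so even a single added heavy atom at this carbon, meta to a fused ring and para to a fused ring, is enough to move the number beyond the usual scatter. Alongside a 2.3-fold lower number from compound 1 to compound 2 (0.36 log units; beyond the scatter), where a methoxy enters the same ring at a different place, this is a second case in which a group on this ring goes with a lower number than hydrogen, although both steps are modest and a single example at each place is thin support for a trend. No measurement shown gives a reason for the change from hydrogen to fluoro.

On these data alone, what remains open is whether the gain is specific to fluoro or would also appear with another small group at this carbon, such as a nitrile, an amine or a methyl. As far as these compounds go, it is also open whether a fluoro would give a similar step at other carbons of this ring, or whether it would add to the effect of the methoxy if both stood on the same molecule.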